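Swapping a ring for a chain at the benzimidazole-type anchor

A few compounds are considered here, and "the series" means these few. Any claim that something is new, unique, unknown or untested is made for them only; others in the source may bear on it.

Measured so far:
compound 1 `COc1cc(Cc2nc3c(N)ncnc3n2CC2CCCO2)cc(OC)c1OC` — 91200 nM
compound 2 `COc1cc(Cc2nc3c(N)nc(F)nc3n2CC2CCCO2)cc(OC)c1OC` — 22900 nM

Both were tested in a functional assay on MCF7 cells (Homo sapiens) for antiproliferative activity; on this read-out higher numbers stand for weaker inhibition and lower numbers for stronger inhibition. Compound 1 gives the highest number of the two; its nearest neighbour is compound 2, reached by a 4.0-fold lower number from compound 1 to compound 2 (0.60 log units; beyond the scatter) when fluoro takes the place of hydrogen on an aromatic carbon.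

Compound 3 `CCC(C)Cn1c(Cc2cc(OC)c(OC)c(OC)c2)nc2c(N)ncnc21` has not yet been measured. It differs from compound 1 in one place: sec-butyl in place of oxolan-2-yl on a saturated chain carbon bound to an aromatic nitrogen. The five-membered ring with its one oxygen is gone and a plain branched chain stands in its stead, while the shared core and the trimethoxy-bearing benzyl group are untouched.

Going by the values given here, the only measured step, from compound 1 to compound 2, concerns a different place on the core and says nothing about this exchange. Among the compounds with values here, no measured pair shows what replacing the oxolan-2-yl by sec-butyl does. With nothing to point either way, a step no larger than the scatter is expected: for compound 3 the estimate is 91000 nM, within 30000 nM to 250000 nM, which is expected to mean a 1.0-fold lower number from compound 1 to compound 3 (0.00 log units; within the scatter).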

Compound 3, half-maximal inhibitory concentration: 61700 nM
For compound 3 the middle estimate is 1.5-fold (0.17 log units) above the measured one, within the range that was stated.
By their numbers in this assay, from the lowest: compound 2; then compounds 3 and 1 (each within the scatter of the next).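

In this assay, putting sec-butyl in place of oxolan-2-yl on a saturated chain carbon bound to an aromatic nitrogen gives a 1.5-fold lower number from compound 1 to compound 3 (0.17 log units; within the scatter) and so opens a first view of this position, which the fluoro step on the shared core could not give. The ring and its oxygen, the hydrogen-bond acceptor of this group, can both be exchanged for a plain branched chain without a step beyond the usual scatter, so in this cell read-out neither is shown to matter here. Going by these compounds alone, with only one exchange at this position, this holds for this pair alone, and no measurement on these compounds bears on what lies behind the result.

Still open, as far as these compounds go, is whether any group at this position would move the number beyond the scatter, for example a longer chain such as n-hexyl, a cyclohexyl ring, or a chain ending in a primary amine or a carboxylic acid. Also open, from the compounds shown here alone, is whether the fluoro exchange that separates compound 1 from compound 2 would give a similar step on the core of compound 3, which carries sec-butyl instead of oxolan-2-yl.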